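A Terminal Hydroxy Moved to a Longer Chain

The source may hold more compounds than are shown below. What is called first, only, known or untested is meant among the compounds shown, and "the series" means these compounds.

Compound 1 `CCCCCCOc1ccc2c(=O)c(-c3ccc(O)cc3)coc2c1` carries the shared core with a plain saturated chain on an aromatic oxygen. In an assay (Cricetulus griseus) for inhibition of aldehyde dehydrogenase, mitochondrial (Homo sapiens) (on this read-out higher numbers stand for weaker inhibition and lower numbers for stronger inhibition), compound 1 gives 1500 nM. Compound 2 `O=c1c(-c2ccc(O)cc2)coc2cc(OCCCCCCO)ccc12` differs from it by hydroxy in place of hydrogen on a saturated chain carbon, six bonds along the chain from an oxygen on an aromatic ring, and in this assay compound 2 gives 120 nM. That change produced a 13-fold lower number from compound 1 to compound 2 (1.10 log units; beyond the scatter). Compound 3 `CCCCCCCCCCCCOc1ccc2c(=O)c(-c3ccc(O)cc3)coc2c1` differs from compound 1 by hexyl in place of hydrogen on a saturated chain carbon, six bonds along the chain from an oxygen on an aromatic ring. In this assay compound 3 reaches only a limit of the assay, > 9000 nM, as the limit of > 9000 nM in this assay, at which 1 of the 3 values shown sits, records. This gave an at least 6.0-fold higher number from compound 1 to compound 3 (0.77 log units; beyond the scatter), and against compound 2 it gave an at least 75-fold higher number from compound 2 to compound 3 (1.87 log units; beyond the scatter).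

Compound 4 `O=c1c(-c2ccc(O)cc2)coc2cc(OCCCCCCCCCCCCO)ccc12` has not yet been measured; it differs from compound 3 by hydroxy in place of hydrogen on a saturated chain carbon, ten or more bonds along the chain from an oxygen on an aromatic ring. This is the same kind of change as from compound 1 to compound 2, though there the hydroxy sits six bonds along the chain from an oxygen on an aromatic ring, whereas here it sits at a different place on the chain, as the two differences state. If the hydroxy acts as it did before, compound 4 is expected to show a step of about an at least 3.6-fold lower number from compound 3 to compound 4 (0.55 log units; beyond the scatter) in this assay, resting on a 13-fold lower number from compound 1 to compound 2 (1.10 log units; beyond the scatter), though the limit for compound 3 leaves the starting point uncertain. Compound 4 is therefore estimated at 2500 nM, between 500 nM and 12000 nM.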

Compound 4, half-maximal inhibitory concentration: 1700 nM
Estimate against measurement, compound 4: 1.5-fold (0.17 log units) above; measured number inside the range.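

In this assay, hydroxy in place of hydrogen on the longer chain gave an at least 5.2-fold lower number from compound 3 to compound 4 (0.72 log units; beyond the scatter), the same direction as on the shorter chain. The two hydroxy compounds still do not match, with a 14-fold higher number from compound 2 to compound 4 (1.15 log units; beyond the scatter), and the longer hydroxy chain only brings the number back level with the plain shorter chain, with a 1.1-fold higher number from compound 1 to compound 4 (0.05 log units; within the scatter). Compound 3 stands at a limit of the assay, > 9000 nM. The direction of the change therefore carried from one core to the other in these two cases, but whether its size carried as well is not settled: the same change on two cores in this assay, a 13-fold lower number (1.10 log units; beyond the scatter) from compound 1 to compound 2 and an at least 5.2-fold lower number (0.72 log units; beyond the scatter) from compound 3 to compound 4; the limit leaves it open whether they differ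

The compounds shown do not say how the effect of the hydroxy depends on chain length, since only two chain lengths appear, and a shorter chain or a still longer chain would test this. They also leave open whether an amine or a carboxylic acid in place of the hydroxy would lower the number in the same way.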